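Adding a Methoxy Group to the Core of Compound 1

This account rests on a few compounds, and the source may have more. Where it says the series, first, only, none or still open, it means among the compounds named here.

Compound 1 `COc1ccc(-c2[nH]c3ccccc3c2/C=C(\C#N)S(=O)(=O)c2ccccc2)cc1`: 1200 nM
Compound 2 `CCOC(=O)C(=Cc1c(-c2ccccc2)[nH]c2ccccc12)C(=O)OCC`: 8900 nM

Of the compounds shown here, two have been measured in a functional assay on Malme-3M cells (Homo sapiens) for inhibition, read by sulforhodamine B assay, with a stated time of 48 h; on this read-out lower numbers stand for stronger inhibition of growth and higher numbers for weaker inhibition of growth. Compound 1 gives 1200 nM, the lowest of the two numbers, and compound 2 gives 8900 nM, a higher number that lies beyond the usual scatter of this assay. Among the compounds with values here, the two compounds differ in several places at once, so their values show only that compound 1 inhibits growth more strongly.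

Compound 3 `COc1ccc(-c2[nH]c3ccc(OC)cc3c2/C=C(\C#N)S(=O)(=O)c2ccccc2)cc1` has not yet been measured. It differs from compound 1 by methoxy in place of hydrogen on an aromatic carbon. For a change of this kind nothing in the measured pair points in either direction, so the expected step of a 1.1-fold lower number from compound 1 to compound 3 (0.04 log units; within the scatter) is one of no size beyond the scatter. Compound 3 is therefore estimated to give 1100 nM, within a range of 400 nM to 3200 nM.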

Compound 3, concentration for 50% growth inhibition: 3200 nM
Estimate against measurement, compound 3: 2.9-fold (0.46 log units) below; the range from low to high includes it.
By their numbers in this assay, from the lowest: compound 1; then compound 3; then compound 2.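

In this assay, methoxy in place of hydrogen on this aromatic carbon of the shared core gives a 2.7-fold higher number from compound 1 to compound 3 (0.43 log units; beyond the scatter), a modest step towards weaker inhibition of growth. Within the data shown here, this is the first single change that can be read, and it shows that this carbon does not tolerate the change without cost, since the hydrogen of compound 1 gives the stronger inhibition. Nothing shown gives a reason for this step.

The compounds shown leave open whether the step belongs to methoxy itself or would follow any group placed on this carbon. On these data alone, whether a fluorine or an amine here would give a lower or a higher number than compound 1 stays open, as does the effect of methoxy on another carbon of the core.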